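Replacing chloro in compound 3 at the assay limit

This account rests on a few compounds, and the source may have more. Where it says the series, first, only, none or still open, it means among the compounds named here.

Measured so far in an ADME assay on Raji cells (Homo sapiens) for cytotoxicity, read by luminescence, with a stated time of 72 h; on this read-out higher numbers stand for an effect only at larger amounts of compound and lower numbers for an effect already at smaller amounts
- compound 1 (`CCOC(=O)c1c(-c2cccc(Cl)c2)[nH]c2cc(OC)ccc2c1=O`) gives > 21500 nM as a limit
- compound 2 (`CCOC(=O)c1c(-c2cccc(Cl)c2)[nH]c2cc(OC)c(Cl)cc2c1=O`) gives > 21500 nM as a limit
- compound 3 (`CCOC(=O)c1c(-c2cccc(Cl)c2)[nH]c2cc(OC)c(F)cc2c1=O`) gives > 21500 nM as a limit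

Compound 3 stands at > 21500 nM and this is a limit. The whole series offers only the limit of > 21500 nM in this assay, at which 3 of the 3 values shown sit, and so no order among the three compounds can be read.

Compound 4 (`CCOC(=O)c1c(-c2cccc(-c3nc(C)c(C)s3)c2)[nH]c2cc(OC)c(F)cc2c1=O`) has 4,5-dimethyl-1,3-thiazol-2-yl in place of chloro on an aromatic carbon of a six-membered aromatic ring of carbon only, meta to a large group (4,5-dimethyl-1,3-thiazol-2-yl in place of chloro on an aromatic carbon). Three measured steps stand nearby. They are a step that the two limits leave unreadable from compound 1 to compound 2 and a step that the two limits leave unreadable from compound 1 to compound 3 and a step that the two limits leave unreadable from compound 2 to compound 3 and none of them touches the chloro that leaves in compound 4. None has a readable size, so they give no direction for this much larger change.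

The expectation therefore rests on compound 3 with > 21500 nM as its limit, and compound 4 will most likely report a limit too. In this assay the expected change is a step that the limit leaves unreadable from compound 3 to compound 4 and no direction can be given for it. Compound 4 is estimated at 22000 nM (expected range 8000 nM to 40000 nM).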

Compound 4, half-maximal effective concentration: > 21500 nM
Compound 4: a limit, no number (the forecaster's own chance of this, stated with the estimate: 75%); the middle value does not contradict the limit.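

In this assay, among the compounds shown here, compound 4 gives > 21500 nM, which is a limit, so no step from compound 3 to compound 4 can be read. The compounds shown leave open at what concentration any of them would reach a half-maximal effect, and whether 4,5-dimethyl-1,3-thiazol-2-yl in place of chloro changes it at all: the limit of > 21500 nM in this assay, at which 4 of the 4 values shown sit.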